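This account rests on a few compounds, and the source may have more. Where it says the series, first, only, none or still open, it means among the compounds named here.

Measured compounds, each with its value in a functional assay, read by spectrophotometry, with a stated time of 5 min; a lower number here means a stronger inhibitor, a higher number a weaker inhibitor:
Compound 1, `O=c1[nH]c2ccccc2cc1/C=N/O`, gives 463000 nM.
Compound 2, `Cc1ccc2[nH]c(=O)c(/C=N/O)cc2c1`, gives 389000 nM.
Compound 3, `O=C(O)c1ccc(/N=C/c2cc3ccccc3[nH]c2=O)cc1`, gives 381000 nM.

Compound 2 differs from compound 1 by methyl in place of hydrogen on an aromatic carbon, and this gave a 1.2-fold lower number from compound 1 to compound 2 (0.08 log units; within the scatter). Compound 4, `Cc1ccc2[nH]c(=O)c(/C=N/c3ccc(C(=O)O)cc3)cc2c1`, has not been measured yet; it differs from compound 3 by methyl in place of hydrogen on an aromatic carbon, the same change at the same kind of place. The difference between the core of compound 1 and the core of compound 3 is not broken down here; the values of compound 1 and compound 3 lie within the scatter of each other. Since the earlier step stayed within the scatter, the step from compound 3 to compound 4 in this assay is expected to be small as well, estimated as a 1.2-fold lower number from compound 3 to compound 4 (0.08 log units; within the scatter), resting on a 1.2-fold lower number from compound 1 to compound 2 (0.08 log units; within the scatter). Compound 4 is thus estimated at 320000 nM, expected to fall between 150000 nM and 700000 nM.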

Compound 4, half-maximal inhibitory concentration: 409000 nM
Compound 4: the middle estimate sits 1.3-fold (0.11 log units) below what was measured; the range from low to high includes it.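

In this assay, methyl in place of hydrogen on an aromatic carbon gives a 1.1-fold higher number from compound 3 to compound 4 (0.03 log units; within the scatter). Set beside the earlier step, the change looks the same on both cores, with no difference beyond the scatter: the same change on two cores in this assay, a 1.2-fold lower number (0.08 log units; within the scatter) from compound 1 to compound 2 and a 1.1-fold higher number (0.03 log units; within the scatter) from compound 3 to compound 4, 1.3-fold (0.11 log units) apart, within the scatter of two such steps. This shows that the methyl made no detectable difference on either of these two cores, at this one place and in this one assay, but it does not show that the same would hold on any other core, and two small steps cannot show whether a large effect would carry over.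

The compounds shown leave open whether a different group at this place, such as an amine or a longer chain, would shift the number beyond the scatter. Also open, going by these compounds, is what a methyl would do on the other aromatic carbons.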